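The source may hold more compounds than are shown below. What is called first, only, known or untested is meant among the compounds shown, and "the series" means these compounds.

Measured compounds:
Compound 1, `Cc1nc2c(cnn2S(=O)(=O)c2ccc(Cl)cc2)c(=O)n1/N=C/c1ccccc1`, in a functional assay on MCF7 cells (Homo sapiens) for cytotoxicity, read by colorimetric assay and sulforhodamine B assay, with a stated time of 48 h (on this read-out lower numbers stand for stronger inhibition and higher numbers for weaker inhibition), gives 22400 nM.
Compound 2, `COc1ccc(/C=N/n2c(C)nc3c(cnn3S(=O)(=O)c3ccc(Cl)cc3)c2=O)cc1`, in this assay gives 41900 nM.

Of these two numbers compound 2 carries the higher one, but the step of a 1.9-fold higher number from compound 1 to compound 2 (0.27 log units; within the scatter) lies within the usual scatter of repeated measurements, so the two compounds cannot really be told apart on this read-out.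

Compound 3, `COc1ccc(/C=N/n2c(C)nc3c(cnn3S(=O)(=O)c3ccc(Cl)cc3)c2=O)cc1OC`, has not yet been measured. It differs from compound 2 by methoxy in place of hydrogen on an aromatic carbon: a second methoxy enters the same six-membered ring of carbon only, ortho to the methoxy group already present, so that the 4-methoxyphenyl group becomes a 3,4-dimethoxyphenyl group. Among the measured compounds shown here, only one measured step bears on this change, the step of a 1.9-fold higher number from compound 1 to compound 2 (0.27 log units; within the scatter), in which the first methoxy entered that ring; it stayed within the scatter. On that basis, for compound 3 in this assay a step of about a 1.1-fold higher number from compound 2 to compound 3 (0.03 log units; within the scatter) is expected, which is no change beyond the scatter in either direction. The estimate for compound 3 is 45000 nM, with a range from 18000 nM to 110000 nM.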

Compound 3, half-maximal inhibitory concentration: 33600 nM
Estimate against measurement, compound 3: 1.3-fold (0.13 log units) above, within the range that was stated.
By their numbers in this assay, from the lowest: compounds 1, 3 and 2 (each within the scatter of the next).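

In this assay the second methoxy, which turns the 4-methoxyphenyl group into a 3,4-dimethoxyphenyl group, gives a step that cannot be told from the usual scatter (a 1.2-fold lower number from compound 2 to compound 3 (0.10 log units; within the scatter)), so this place on the ring, ortho to a methoxy group, accepts the extra group with no measurable effect. The earlier compounds shown here showed only what a single methoxy does; now the full change from the phenyl group to the 3,4-dimethoxyphenyl group can be read as well, and it also stays within the scatter (a 1.5-fold higher number from compound 1 to compound 3 (0.18 log units; within the scatter)), which means that none of the three compounds can be separated from the others on this read-out. Nothing shown here offers an explanation for why these numbers stay so close together.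

From the compounds shown here alone, it remains open whether a different kind of group on this ring, such as an amine, a carboxylic acid or a longer chain in place of the methoxy, would move the number beyond the scatter. Going by these compounds, it is also open whether the shared core would respond to a change made anywhere other than this ring.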